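The compounds below may be only part of what the source reports. "The series", "measured", "known", "first", "only" and "open" are said of these compounds alone.

Measured so far in the same cellular test:

- compound 1 `COc1cc(NC(C)CCCNC(=O)NNC(=O)Nc2cc(C(F)(F)F)cc(C(F)(F)F)c2)c2ncccc2c1`: 20000 nM
- compound 2 `COc1cc(NC(C)CCCNC(=O)Nc2ccc(O)cc2)c2ncccc2c1`: 57000 nM
- compound 3 `COc1cc(NC(C)CCCNC(=O)NNC(=O)Nc2ccc(C(F)(F)F)cc2)c2ncccc2c1`: 19000 nM

These numbers come from a functional assay on MIA PaCa-2 cells (Homo sapiens) for inhibition, read by MTT assay, with a stated time of 72 h; on this read-out higher numbers stand for weaker inhibition and lower numbers for stronger inhibition. Compound 2 stands highest of the three; compound 1 and compound 3 both lie below it by more than the usual scatter, so compound 2 is the weakest inhibitor among them.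

Compound 4 `COc1cc(NC(C)CCCNC(=O)Nc2ccc(Br)cc2)c2ncccc2c1` keeps the shared core and changes only the group on the phenyl ring: bromo in place of hydroxy on an aromatic carbon

For the measured compounds named here, no measured pair shows this exact change, so the expected size of the step in this assay rests on the surrounding numbers alone. A modest step toward stronger inhibition seems most likely, roughly at the edge of the scatter, though no change beyond it would not surprise. Compound 4 is therefore estimated at 30000 nM (range 10000 nM to 90000 nM), which means an expected step of a 1.9-fold lower number from compound 2 to compound 4 (0.28 log units; within the scatter).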

Compound 4, half-maximal inhibitory concentration: 23000 nM
Estimate against measurement, compound 4: 1.3-fold (0.12 log units) above; the range from low to high includes it.
By their numbers in this assay, from the lowest: compounds 3, 1 and 4 (each within the scatter of the next); then compound 2.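

In this assay, for the compounds shown here, bromo in place of hydroxy gives a 2.5-fold lower number from compound 2 to compound 4 (0.39 log units; beyond the scatter), the first direct evidence that the group on this aromatic carbon, para to a large group, affects the result, though only modestly. The hydroxy has a hydrogen-bond donor and acceptor and the bromo has neither, yet inhibition is stronger, so neither feature is required for activity at this level. Nothing available explains the step. On these data alone, whether chloro, an amine or a carboxylic acid at this place would give a similar number remains open. So does whether any replacement could bring a larger step.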